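Deazapurine nucleoside series: anilino to sulfanyl on the ring carbon

This account rests on a few compounds, and the source may have more. Where it says the series, first, only, none or still open, it means among the compounds named here.

Three compounds carry a measurement so far. Compound 1 `[O-][n+]1ccc2c(c1)ncn2[C@H]1C[C@H](O)[C@@H](CO)O1` gives 0% in a functional assay (Homo sapiens) for inhibition of Nucleic Acid, tested at 100 uM; a lower number here means less inhibition, a higher number more inhibition at the concentration tested (going by the name of the read-out). Compound 2 `OC[C@H]1OC(n2cnc3c(Nc4ccccc4)nccc32)[C@H](O)[C@@H]1O` gives 4% in this assay, and compound 3 `OC[C@H]1O[C@@H](n2cnc3c(S)nccc32)C[C@@H]1O` gives 10%. Compound 2 stands second highest of the three numbers; its nearest neighbour is compound 1, a few points lower and within the scatter, and its furthest is compound 3, a few points higher and likewise within the scatter. The three values therefore do not separate from one another.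

Compound 4 `OC[C@H]1OC(n2cnc3c(S)nccc32)[C@H](O)[C@@H]1O` has not been measured. Relative to compound 2 the change is sulfanyl in place of anilino on an aromatic carbon. Among the measured compounds shown here, the same sulfanyl group is present in compound 3 on a different sugar, where the reading was 10%, so nothing among the measured compounds points to a shift beyond the scatter. For compound 4 the expected step of a number 3 percentage points higher from compound 2 to compound 4 (within the scatter) is therefore small, with no direction claimed beyond the scatter. The estimate for compound 4 is 7%, within 0% to 18%.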

Compound 4, a percentage reported as inhibition, at one concentration (the size of the read-out at that concentration, not a potency): 6%
The estimate for compound 4 lay 1 percentage points above the measured number; the range from low to high includes it.
By their numbers in this assay, from the lowest: compounds 1, 2, 4 and 3 (each within the scatter of the next).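

With the sugar unchanged, sulfanyl in place of anilino on an aromatic carbon, next to the ring nitrogen, gives a number 2 percentage points higher from compound 2 to compound 4 (within the scatter) in this assay. Among the compounds shown here, removing the six-membered aromatic ring of carbon only therefore does not move the read-out beyond the scatter at this position, which the earlier compounds, differing from one another in more than one place, could not show. Nothing measured offers an explanation for this result.

On these data alone, both readings are low at a single concentration, so it remains open whether any group at this position can move inhibition beyond the scatter. An amine or a carboxylic acid on this aromatic carbon, or a longer chain on the sulfur, would address that question.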